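Anilide Variation on a Shared Core: Cytotoxicity Outlook

The compounds below may be only part of what the source reports. "The series", "measured", "known", "first", "only" and "open" are said of these compounds alone.

Compound 1 `COc1ccc2c(=O)c(/C=C/C(=O)Nc3cccc(C)c3)coc2c1` gives 554000 nM in an ADME assay on HepG2 2.2.15 cells (Homo sapiens) for cytotoxicity, read by MTT assay, with stated times of 48 h and 9 days; a lower number here means that less compound is tolerated, a higher number that more compound is tolerated. Compound 2 `COc1ccc2c(=O)c(/C=C/C(=O)Nc3ccccc3)coc2c1` gives 523000 nM in this assay. Compound 3 `COc1ccc2c(=O)c(/C=C/C(=O)Nc3cc(C)ccc3C)coc2c1` gives 1100000 nM in this assay.

Compound 1 stands second highest of the three; its nearest neighbour is compound 2, with a 1.1-fold lower number from compound 1 to compound 2 (0.03 log units; within the scatter), and its furthest is compound 3, with a 2.0-fold higher number from compound 1 to compound 3 (0.30 log units; within the scatter). Compound 4 `COc1ccc2c(=O)c(/C=C/C(=O)Nc3ccc(Cl)cc3)coc2c1` differs from compound 1 by 4-chlorophenyl in place of 3-methylphenyl on an amide-type nitrogen. The measured steps speak only to methyl groups: a 1.1-fold lower number from compound 1 to compound 2 (0.03 log units; within the scatter) and a 2.1-fold higher number from compound 2 to compound 3 (0.32 log units; beyond the scatter), the latter modest. Within the data shown here, no measured step covers a chlorine. Compound 4 is therefore expected to show a step of a 1.1-fold lower number from compound 1 to compound 4 (0.04 log units; within the scatter), not beyond the scatter. Compound 4 is estimated at 500000 nM, with a range from 250000 nM to 1100000 nM.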

Compound 4, half-maximal cytotoxic concentration: 272000 nM
Beside the measured number, compound 4's estimate is 1.8-fold (0.26 log units) above it; low and high end bracket the measured number.
By their numbers in this assay, from the lowest: compounds 4, 2, 1 and 3 (each within the scatter of the next, the first and the last beyond it).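

Among these compounds, the chlorine brings the first downward steps beyond the scatter at this amide-type nitrogen in this assay: a 2.0-fold lower number from compound 1 to compound 4 (0.31 log units; beyond the scatter) and a 4.0-fold lower number from compound 3 to compound 4 (0.61 log units; beyond the scatter) are both modest. Against the unsubstituted phenyl, however, chloro in place of hydrogen gives a 1.9-fold lower number from compound 2 to compound 4 (0.28 log units; within the scatter) and so does not separate compound 4 from compound 2. No evidence is available to explain these steps. The compounds shown leave open how this assay would read a phenyl carrying an amine or a carboxylic acid in place of the chlorine.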